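The source may hold more compounds than are shown below. What is called first, only, known or untested is meant among the compounds shown, and "the series" means these compounds.

Compound 1, with the structure `COc1ccccc1S(=O)(=O)/C=C/c1ccccn1`, was tested in an assay on U2OS cells for activation of nuclear factor erythroid 2-related factor 2 (Homo sapiens), read by chemiluminescence, with a stated time of 6 h (a higher number here means that more compound is needed for the effect, a lower number that less compound is needed), where compound 1 gives 9070 nM. Compound 2, `COc1ccccc1S(=O)(=O)/C=C/c1cccc(Cl)n1`, differs from it by a single change: chloro in place of hydrogen on an aromatic carbon. In this assay compound 2 gives 1160 nM, so the step of a 7.8-fold lower number from compound 1 to compound 2 (0.89 log units; beyond the scatter) is a clear gain. Compound 3, `COc1ccc(S(=O)(=O)/C=C/c2ccccn2)cc1`, is built from the same atoms as compound 1 but joined differently; how the two cores differ is not broken down here. In this assay compound 3 reaches only a limit, > 10000 nM, which is the limit of > 10000 nM in this assay, at which 1 of the 3 values shown sits. Compound 4, `COc1ccc(S(=O)(=O)/C=C/c2cccc(Cl)n2)cc1`, has not yet been measured; it stands to compound 3 as compound 2 stands to compound 1, through the same change, (chloro in place of hydrogen on an aromatic carbon), at a place described in the same words. If that step repeats with about the same size, the expected step is an at least 2.5-fold lower number from compound 3 to compound 4 (0.39 log units; beyond the scatter). Because the starting point of compound 3 is known only as > 10000 nM, the value of compound 4 is uncertain and is estimated at 4000 nM, expected to fall between 1200 nM and 15000 nM.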

Compound 4, half-maximal effective concentration: 3270 nM
The estimate for compound 4 lay 1.2-fold (0.09 log units) above the measured number; the measured number falls inside the stated range.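

In this assay, chloro in place of hydrogen on an aromatic carbon again goes with a lower number, with an at least 3.0-fold lower number from compound 3 to compound 4 (0.48 log units; beyond the scatter), so the direction of the change carries over from the core of compound 1 to the core of compound 3. Compound 3 stands only at a limit, > 10000 nM, and is not a true number. This means the direction is shown, but not whether the size of the gain is the same on both cores, as setting the two steps side by side makes plain: the same change on two cores in this assay, a 7.8-fold lower number (0.89 log units; beyond the scatter) from compound 1 to compound 2 and an at least 3.0-fold lower number (0.48 log units; beyond the scatter) from compound 3 to compound 4; the limit leaves it open whether they differ

The compounds shown compare only hydrogen and chloro at this place, so it stays open whether fluoro, methyl, an amine or a nitrile there would give a similar drop or a different one. On these data alone, it also stays open whether the gain from chloro would hold on any core beyond these two.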